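Compound 4: A New Aryl Group on the Shared Core

This account rests on a few compounds, and the source may have more. Where it says the series, first, only, none or still open, it means among the compounds named here.

Measured so far in a physicochemical assay for solubility; on this read-out lower numbers stand for lower solubility and higher numbers for higher solubility
Compound 1 `Cc1ccc(-c2cc(C(F)(F)F)ccc2[C@H]2CCOc3cc(S(=O)(=O)Nc4ncc(F)cn4)ccc32)cn1` at 225000 nM
Compound 2 `Cn1nccc1-c1cc(C(F)(F)F)ccc1[C@H]1CCOc2cc(S(=O)(=O)Nc3ccc(F)cn3)ccc21` at 29000 nM
Compound 3 `Cc1ccc(-c2cc(C(F)(F)F)ccc2[C@H]2CCOc3cc(S(=O)(=O)Nc4ccncn4)ccc32)cn1` at 181000 nM

Compound 3 (181000 nM) lies within the scatter of compound 1, and both lie beyond the scatter above compound 2 on this read-out. Compound 4 `O=S(=O)(Nc1ccncn1)c1ccc2c(c1)OCC[C@@H]2c1ccc(C(F)(F)F)cc1-c1ccc(F)cn1` has yet to be measured. It carries 5-fluoropyridin-2-yl in place of 6-methylpyridin-3-yl on an aromatic carbon, ortho to a large group and meta to a trifluoromethyl group (5-fluoropyridin-2-yl in place of 6-methylpyridin-3-yl on an aromatic carbon) while the rest of compound 3 stays the same.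

For the measured compounds named here, no measured step changes this place alone. Going by the values given here, the one step available (a 1.2-fold lower number from compound 1 to compound 3 (0.09 log units; within the scatter)) concerns a sulfonamide nitrogen, where pyrimidin-4-yl replaces 5-fluoropyrimidin-2-yl, so it gives no size for this change. Compound 2 (29000 nM) has another group at this place but also differs on the sulfonamide nitrogen, so its value shows only that the two differences together can come with a lower number. On that thin evidence, a moderate move towards a lower number is expected, with wide uncertainty. The expected step in this assay is a 2.3-fold lower number from compound 3 to compound 4 (0.35 log units; beyond the scatter) by this estimate. Compound 4 is estimated at 80000 nM with an expected range from 25000 nM to 200000 nM for the coming measurement.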

Compound 4, solubility: 181000 nM
Compound 4: the middle estimate sits 2.3-fold (0.35 log units) below what was measured; low and high end bracket the measured number.
By their numbers in this assay, from the lowest: compound 2; then compounds 3, 4 and 1 (each within the scatter of the next).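

Here the aryl group ortho to a large group and meta to a trifluoromethyl group is changed alone for the first time, with pyrimidin-4-yl held on the sulfonamide nitrogen and the rest of the shared core fixed. In this assay the exchange of 6-methylpyridin-3-yl for 5-fluoropyridin-2-yl gives no change at the digits printed from compound 3 to compound 4 (within the scatter) and so shows that, on this background, this position tolerates the change without any step beyond the scatter. No measured evidence offers a reason for this flat step.

The compounds shown leave open whether the same exchange would read as flat with 5-fluoropyrimidin-2-yl on the sulfonamide nitrogen, and how much of the low number of compound 2 at 29000 nM belongs to its group at this position rather than to its different group on that nitrogen. They also leave open how this assay would read with an amine or a carboxylic acid attached to the aryl group at this position, since both groups compared so far here are simple substituted pyridines.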